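Swapping the ethylamino group for dipropylamino

The source may hold more compounds than are shown below. What is called first, only, known or untested is meant among the compounds shown, and "the series" means these compounds.

Of the compounds shown here, three have been tested so far in a functional assay on the whole organism with Canis familiaris (Canis lupus familiaris) as the target, at a dose of 5 mg/kg by the intravenous route; on this read-out lower numbers stand for a weaker effect and higher numbers for a stronger effect at the one dose given. Compound 1 `Cc1nc2c(COc3ccccc3)cccn2c1N` gives 34%. Compound 2 `CCNc1c(C)nc2c(OCc3ccccc3)cccn12` gives 70%, the highest of the three numbers, and its step up from compound 1 lies beyond the usual scatter. Compound 3 `CCNc1c(C)nc2c(OCc3ccccc3)nccn12`, which carries a different ring nitrogen pattern in its core, gives 0%, the lowest of the three.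

Compound 4 `CCCN(CCC)c1c(C)nc2c(OCc3ccccc3)cccn12` has not yet been measured in this assay. It differs from compound 2 in one place: dipropylamino in place of ethylamino on an aromatic carbon. The group that enters is larger and brings no hydrogen-bond donor, where the ethylamino group it replaces had one.

Going by the values given here, no measured pair shows what this kind of swap does, so the direction is open. A moderate weakening, reaching just beyond the scatter, is expected, as a step of a number 18 percentage points lower from compound 2 to compound 4 (beyond the scatter). Compound 4 is therefore estimated to give 52%, within a range from 20% to 80%.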

Compound 4, a percentage reported as inhibition, in the whole organism at one dose (the size of the read-out at that dose, not a potency): 0%
Compound 4: the middle estimate sits 52 percentage points above what was measured, outside the stated range (below it).
By their numbers in this assay, from the lowest: compounds 3 and 4 (each within the scatter of the next); then compound 1; then compound 2.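

Going by these compounds alone, the first pair that differs in one place shows that the group on this aromatic carbon matters greatly in this assay: dipropylamino in place of ethylamino gives a number 70 percentage points lower from compound 2 to compound 4 (beyond the scatter), and compound 4 gives 0% at the one dose tested. The swap changes two counted features together, going from 3 to 7 heavy atoms and from 1 hydrogen-bond donor to 0 hydrogen-bond donors, so this pair cannot show which of them goes with the lower number. Nothing available explains the drop.

On these data alone, it remains open whether the loss follows from the longer chains or from the missing amine hydrogen. Propylamino, which keeps that hydrogen on a longer chain, and dimethylamino, which lacks it on shorter chains, would help separate the two.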